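Swapping Pyrimidine for Fluoropyridine on a Sulfonamide Nitrogen

A few compounds are considered here, and "the series" means these few. Any claim that something is new, unique, unknown or untested is made for them only; others in the source may bear on it.

Of the compounds shown here, two sharing one core have been measured in a physicochemical assay for lipophilicity; on this read-out lower numbers stand for lower lipophilicity and higher numbers for higher lipophilicity. Compound 1 `Cn1nccc1-c1cc(C(F)(F)F)ccc1[C@H]1CCOc2cc(S(=O)(=O)Nc3ccncn3)ccc21` gives 1.8. Within the data shown here, compound 2 `Cn1nccc1-c1cc(C(F)(F)F)ccc1[C@H]1CCOc2cc(S(=O)(=O)Nc3ncccn3)ccc21` gives 3.7, the higher of the two numbers; the only step so far, a number 1.90 log units higher from compound 1 to compound 2 (beyond the scatter), exchanges pyrimidin-4-yl for pyrimidin-2-yl on a sulfonamide nitrogen. Compound 3 `Cn1nccc1-c1cc(C(F)(F)F)ccc1[C@H]1CCOc2cc(S(=O)(=O)Nc3ccc(F)cn3)ccc21` has not yet been measured. The change from compound 2 to compound 3 is 5-fluoropyridin-2-yl in place of pyrimidin-2-yl on a sulfonamide nitrogen. Among the measured compounds shown here, no measured step repeats this exchange: the single step, a number 1.90 log units higher from compound 1 to compound 2 (beyond the scatter), merely swaps two pyrimidinyl groups and keeps the ring type, so it bears on the new step only by showing that this position alone can move the read-out by a large amount. As pyrimidin-2-yl gives way to 5-fluoropyridin-2-yl, a moderate step upward in this assay is expected, although a value within the scatter of compound 2 cannot be excluded. The expected step is a number 0.40 log units higher from compound 2 to compound 3 (beyond the scatter). Compound 3 is therefore estimated at 4.1, within a range from 3.4 to 4.8.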

Compound 3, distribution coefficient: 3.8
For compound 3 the middle estimate is 0.30 log units above the measured one, and the stated range covers the measured number.
By their numbers in this assay, from the lowest: compound 1; then compounds 2 and 3 (each within the scatter of the next).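

On the sulfonamide nitrogen, this assay does not separate pyrimidin-2-yl from 5-fluoropyridin-2-yl: the step is a number 0.10 log units higher from compound 2 to compound 3 (within the scatter), even though the ring goes from 2 hetero atoms to 1 hetero atom and gains a fluorine. The earlier pair showed only that two pyrimidinyl groups can read very differently at this place, whereas this result shows a different ring type reading level with pyrimidin-2-yl, which leaves pyrimidin-4-yl as the group set apart among these three, with a number 2.00 log units higher from compound 1 to compound 3 (beyond the scatter). No separate measurement is available to explain why these groups read as they do.

The compounds shown leave open what the fluorine contributes on its own, a question that a plain pyridin-2-yl group on the same nitrogen would address. Going by these compounds, it also remains open how a group outside this aromatic series, such as a simple methyl or a short chain carrying an amine, would read at this place in this assay.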